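This account rests on a few compounds, and the source may have more. Where it says the series, first, only, none or still open, it means among the compounds named here.

Measured compounds:
Compound 1, `CCNC(=O)c1oc2nc(-c3ccccc3)cc(C(F)(F)F)c2c1N`: in a functional assay on HepG2 cells (Homo sapiens) for antiproliferative activity, read by MTT assay (on this read-out lower numbers stand for stronger inhibition and higher numbers for weaker inhibition), compound 1 gives 42800 nM.
Compound 2, `Nc1c(C(=O)N/N=C/c2ccc(Br)cc2)oc2nc(-c3cccs3)cc(C(F)(F)F)c12`: in this assay compound 2 gives 6100 nM.
Compound 3, `CCNC(=O)c1oc2nc(-c3cccs3)cc(C(F)(F)F)c2c1N`: in this assay compound 3 gives 12100 nM.

Compound 3 stands second highest of the three numbers; compound 2 is nearest to it, and the two lie within the scatter of each other, while compound 1 is furthest, with a 3.5-fold lower number from compound 1 to compound 3 (0.55 log units; beyond the scatter) separating them, a step that concerns the group on the aromatic carbon and not the amide side.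

Compound 4, `Cc1ccc(/C=N/NC(=O)c2oc3nc(-c4cccs4)cc(C(F)(F)F)c3c2N)cc1`, differs from compound 3 only at the amide-type nitrogen: a group of 9 heavy atoms (8 carbon, 1 nitrogen; one six-membered aromatic ring of carbon only) in place of a group of 2 heavy atoms (2 carbon; no ring), on an amide-type nitrogen. Going by the values given here, the one measured step that bears on this place is a 2.0-fold higher number from compound 2 to compound 3 (0.30 log units; within the scatter), where a closely related nine-atom group was exchanged for ethyl and the number moved by an amount inside the scatter. Compound 4 goes the other way, putting a nine-atom group back in place of ethyl, and the entering group differs from that of compound 2 only in its outer substituent. The expected step is therefore small, a 1.9-fold lower number from compound 3 to compound 4 (0.27 log units; within the scatter), toward a somewhat lower number but not clearly beyond the scatter.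

Compound 4 is estimated at 6500 nM, within a range of 2500 nM to 17000 nM.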

Compound 4, half-maximal inhibitory concentration: 19800 nM
Compound 4: the middle estimate sits 3.0-fold (0.48 log units) below what was measured, and the stated range ends below it.
By their numbers in this assay, from the lowest: compounds 2, 3 and 4 (each within the scatter of the next, the first and the last beyond it); then compound 1.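

In this assay, going by these compounds alone, putting the group of 9 heavy atoms with its methyl-bearing aromatic ring on the amide-type nitrogen in place of ethyl gives a 1.6-fold higher number from compound 3 to compound 4 (0.21 log units; within the scatter), so compound 3 and compound 4 cannot be told apart, and this exchange, like the one linking compound 2 with compound 3, stays inside the scatter. The new information lies further out in that group: a 3.2-fold higher number from compound 2 to compound 4 (0.51 log units; beyond the scatter) is a modest step, but it shows that methyl in place of bromo on an aromatic carbon separates two compounds that each stay within the scatter of compound 3. Nothing shown here gives a reason for this difference between bromo and methyl.

As far as these compounds go, with only these two groups compared on that aromatic carbon, it remains open how chloro, methoxy or an amine would fare there, and so whether bromo and methyl mark the ends of a wider spread or only two points within it. Also open, from the compounds shown here alone, is whether a longer chain such as butyl on the amide-type nitrogen would stay as close to ethyl as these larger groups do.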